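Nitro in place of bromo: an expected antiproliferative value

The source may report more compounds than this note shows. Statements on the series, on what has been measured and on what is new or still open speak of the compounds shown alone.

Three compounds have been measured in a functional assay on BGC-823 cells (Homo sapiens) for antiproliferative activity, read by MTT assay, with a stated time of 48 h; on this read-out higher numbers stand for weaker inhibition and lower numbers for stronger inhibition:

compound 1, `O=[N+]([O-])c1ccccc1CSc1nnc(-c2ccc3c(c2)OCCO3)o1`: 23300 nM
compound 2, `Brc1ccccc1CSc1nnc(-c2ccc3c(c2)OCCO3)o1`: 21200 nM
compound 3, `Brc1ccc(CSc2nnc(-c3ccc4c(c3)OCCO4)o2)cc1`: 22300 nM

Compound 1 and compound 3 are each reached from compound 2 by a single change. The difference from compound 2 to compound 1 is nitro in place of bromo on an aromatic carbon and the step is a 1.1-fold higher number from compound 2 to compound 1 (0.04 log units; within the scatter). The difference from compound 2 to compound 3 is 4-bromophenyl in place of 2-bromophenyl on a saturated chain carbon bound to a sulfur and the step is a 1.1-fold higher number from compound 2 to compound 3 (0.02 log units; within the scatter). Compound 1 and compound 3 differ in more than one place; their two values lie within the scatter of each other.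

Compound 4, `O=[N+]([O-])c1ccc(CSc2nnc(-c3ccc4c(c3)OCCO4)o2)cc1`, has not been measured in this assay. It differs from compound 3 by nitro in place of bromo on an aromatic carbon. Among these compounds this change occurs twice. The earlier instance placed the nitro ortho to a large group, whereas in compound 4 it sits para to a large group, so the two are the same kind of change, not the same. The earlier step was a 1.1-fold higher number from compound 2 to compound 1 (0.04 log units; within the scatter). On that single precedent compound 4 is expected to show a step of a 1.1-fold higher number from compound 3 to compound 4 (0.03 log units; within the scatter), within the scatter. Compound 4 is therefore estimated in this assay at 24000 nM, between 12000 nM and 48000 nM.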

Compound 4, half-maximal inhibitory concentration: 23000 nM
For compound 4 the middle estimate is 1.0-fold (0.02 log units) above the measured one, within the range that was stated.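

In this assay, nitro in place of bromo, para to a large group, gives a 1.0-fold higher number from compound 3 to compound 4 (0.01 log units; within the scatter). Set beside the earlier instance of the same change, the step carries from one core to the other with no difference that can be read: the same change on two cores in this assay, a 1.1-fold higher number (0.04 log units; within the scatter) from compound 2 to compound 1 and a 1.0-fold higher number (0.01 log units; within the scatter) from compound 3 to compound 4, 1.1-fold (0.03 log units) apart, within the scatter of two such steps. This shows that, on these two cores, the exchange of bromo for nitro leaves the number where it was, but neither step stands out from the scatter, so it does not show that the two groups are interchangeable on other cores in the series, or that a step of a readable size would carry over in the same way.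

Every compound shown holds either nitro or bromo on that aromatic ring, so what an amine, a carboxylic acid or a methoxy group would do there remains open. Also open, from the compounds shown here alone, is what a longer chain would do in place of the saturated chain carbon bound to the sulfur.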